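The source may report more compounds than this note shows. Statements on the series, on what has been measured and on what is new or still open speak of the compounds shown alone.

In an ADME assay on MCF-10A cells (Homo sapiens) for inhibition, with a stated time of 48 h (a higher number here means a weaker inhibitor, a lower number a stronger inhibitor), three close relatives of one shared core have been examined. Compound 1 `O=C(Nc1ccc(Cl)cc1)N1CCC[C@H]1c1nc(-c2ccccc2F)no1` gives > 50000 nM in this assay, which is a limit of the assay rather than a number. Compound 2 `O=C(Nc1ccc(Cl)cc1)N1CCC[C@H]1c1nc(-c2ccccc2Cl)no1` likewise gives > 50000 nM, again a limit. Compound 3 `O=C(Nc1ccc(Cl)cc1)N1CCC[C@H]1c1nc(-c2cccc(F)c2)no1` gives > 50000 nM, also a limit.

Compound 2 differs from compound 1 by chloro in place of fluoro on an aromatic carbon. Compound 3 differs from compound 1 in its core: 3-fluorophenyl in place of 2-fluorophenyl on an aromatic carbon. The step from compound 1 to compound 2 is a step that the two limits leave unreadable from compound 1 to compound 2, the step from compound 1 to compound 3 is a step that the two limits leave unreadable from compound 1 to compound 3, and the step from compound 2 to compound 3 is a step that the two limits leave unreadable from compound 2 to compound 3; none of them can be sized because every value sits at the limit of > 50000 nM in this assay, at which 3 of the 3 values shown sit.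

Compound 4 `O=C(Nc1ccc(Cl)cc1)N1CCC[C@H]1c1nc(-c2cccc(Cl)c2)no1` has not yet been measured. It differs from compound 3 by chloro in place of fluoro on an aromatic carbon. This is the same kind of change as that from compound 1 to compound 2, though not the same: there the entering chloro sits ortho to a large group, here meta to a large group.

Since the change from compound 1 to compound 2 left the reading at its limit, and compound 3 itself sits at > 50000 nM, compound 4 is expected to stay where its neighbours are, with an expected step that the limit leaves unreadable from compound 3 to compound 4. The estimate for compound 4 in this assay is therefore 60000 nM, expected to lie between 20000 nM and 200000 nM, most probably reported again only as a limit.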

Compound 4, half-maximal inhibitory concentration: > 50000 nM
Compound 4: no number, only a limit; the forecaster's own chance of this, stated with the estimate: 85%; the middle value lies beyond the limit too.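

In this assay compound 4 gives > 50000 nM, which is a limit of the assay and not a number. No step linking compound 4 to compound 1, compound 2 or compound 3 can therefore be read: the limit of > 50000 nM in this assay, at which 4 of the 4 values shown sit.

The compounds shown leave open whether putting chloro in place of fluoro, or 3-chlorophenyl in place of 2-chlorophenyl, changes inhibition at all, and at what concentration any of the four would reach half-maximal inhibition.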